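Amide nitrogen substituents on the shared core: cytotoxicity notes

The source may hold more compounds than are shown below. What is called first, only, known or untested is meant among the compounds shown, and "the series" means these compounds.

Compound 1 `C=CC1=C(C(=O)Nc2ccccc2OC)C(c2ccc(F)cc2)OC1` in a functional assay on HeLa cells (Homo sapiens) for cytotoxicity, read by MTT assay, with a stated time of 24 h; a higher number here means a weaker inhibitor, a lower number a stronger inhibitor: > 100000 nM
Compound 2 `C=CC1=C(C(=O)NCC(C)C)C(c2ccc(F)cc2)OC1` in this assay: > 100000 nM
Compound 3 `C=CC1=C(C(=O)Nc2ccccc2)C(c2ccc(F)cc2)OC1` in this assay: > 100000 nM
Compound 4 `C=CC1=C(C(=O)NCCCCC)C(c2ccc(F)cc2)OC1`: not yet measured in this assay

The value of compound 1 is a limit of the assay and not a number. The same holds for compound 2. Compound 3 likewise stands only at a limit, the point where every measured member of the series sits (the limit of > 100000 nM in this assay, at which 3 of the 3 values shown sit). Because of this the three steps among the measured compounds cannot be read: a step that the two limits leave unreadable from compound 1 to compound 2; a step that the two limits leave unreadable from compound 1 to compound 3; a step that the two limits leave unreadable from compound 2 to compound 3.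

Compound 4 differs from compound 3 in one place: pentyl in place of phenyl on an amide-type nitrogen. The step that bears on it most directly is the exchange of an alkyl chain for the phenyl on the same nitrogen, a step that the two limits leave unreadable from compound 2 to compound 3, which is unreadable; compound 2 with its isobutyl group shows no measurable inhibition either. For the measured compounds named here, no measured step gives a direction, and nothing in the data suggests that a pentyl chain on the amide nitrogen would move compound 4 off the limit.

Compound 4 is therefore expected to remain at the limit, with an estimated value of 150000 nM and a range from 50000 nM to 1000000 nM. The expected step that the limit leaves unreadable from compound 3 to compound 4 is nothing readable beyond the limit.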

Compound 4, half-maximal inhibitory concentration: > 100000 nM
Compound 4 gave a limit, no number; the forecaster's own chance of this, stated with the estimate: 85%; the middle value lies beyond the limit too.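

In this assay compound 4 gives > 100000 nM, a limit of the assay and not a number. No step from compound 1, compound 2 or compound 3 to compound 4 can be read, and the series stays flat at the limit: the limit of > 100000 nM in this assay, at which 4 of the 4 values shown sit.

The compounds shown leave open whether any amide nitrogen substituent on the shared core gives a measurable value in this assay.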